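Moving the methyl branch along the acid chain of compound 1

The source may report more compounds than this note shows. Statements on the series, on what has been measured and on what is new or still open speak of the compounds shown alone.

Compound 1, `CC(CCCC(=O)O)c1cccc(OCc2ccc3ccccc3n2)c1`, gives 500 nM.
Compound 2, `CCCC(CCc1nnn[nH]1)Cc1ccc(OCc2ccc3ccccc3n2)cc1`, gives 32 nM.
Compound 3, `CC(CCc1ccc(OCc2ccc3ccccc3n2)cc1)Cc1nnn[nH]1`, gives 20 nM.

These three compounds share a core and were all tested in a functional assay (lung) for inhibition, with Cavia porcellus as the target; a lower number here means a stronger inhibitor, a higher number a weaker inhibitor. Among them compound 1 has the highest number, and its gaps to compound 2 and to compound 3 both lie beyond the usual scatter of this assay, so it is the weakest inhibitor of the three on the numbers shown. Compound 2 and compound 3 carry their acidic group on a different arm of the core and are not direct neighbours of compound 1, so no single step can be read from them.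

Compound 4, `CC(CCC(=O)O)Cc1cccc(OCc2ccc3ccccc3n2)c1`, has not yet been measured. It differs from compound 1 in one place: 4-carboxy-2-methylbutyl in place of 4-carboxy-1-methylbutyl on an aromatic carbon. The atoms are the same; only the point at which the methyl branch sits on the chain is shifted.

For the measured compounds named here, no measured pair shows this exact change. The expectation for compound 4 in this assay is therefore a step of a 1.3-fold lower number from compound 1 to compound 4 (0.10 log units; within the scatter), a small move that may well fall within the scatter. Compound 4 is estimated at 400 nM, in the range 150 nM to 1200 nM.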

Compound 4, half-maximal inhibitory concentration: 500 nM
Beside the measured number, compound 4's estimate is 1.3-fold (0.10 log units) below it, within the range that was stated.
By their numbers in this assay, from the lowest: compounds 3 and 2 (each within the scatter of the next); then compounds 1 and 4 (each within the scatter of the next).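

In this assay, moving the methyl branch, with 4-carboxy-2-methylbutyl in place of 4-carboxy-1-methylbutyl on an aromatic carbon, brings no change at the digits printed from compound 1 to compound 4 (within the scatter). For the compounds shown here, this is the first direct reading at this position, and it shows that the two placements of the methyl branch cannot be told apart in this assay, although the atoms of the chain are joined differently; compound 2 and compound 3 differ from both compound 1 and compound 4 in more than one place, and no step to them can be read. Nothing available bears on why the two placements read alike.

On these data alone, the result covers only these two placements on this chain, so it remains open whether an unbranched chain, an ethyl branch or a gem-dimethyl group at either carbon would also leave the number unmoved. As far as these compounds go, it also remains open whether the same shift of the methyl branch would read alike with a longer chain, or with an amide in place of the carboxylic acid at the end of the chain.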